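The source may hold more compounds than are shown below. What is called first, only, known or untested is meant among the compounds shown, and "the series" means these compounds.

Compound 1 `Cc1ccccc1-c1nc(CN2CCC(C(=O)NCCCN3CCCC(C(C)C)C3)CC2)c(C)o1`: in a physicochemical assay for solubility, in phosphate buffer, measured as kinetic solubility, at pH 7.4 (a lower number here means a less soluble compound, a higher number a more soluble compound), compound 1 gives > 71 ug/mL, a limit of the assay.
Compound 2 `Cc1ccccc1-c1nc(CN2CCC(C(=O)N3CCN(CCN(C)C)CC3)CC2)c(C)o1`: in this assay compound 2 gives > 67 ug/mL, a limit of the assay.
Compound 3 `Cc1cccc(-c2nc(CN3CCC(C(=O)NCCCN4C[C@H](C)C[C@H](C)C4)CC3)c(C)o2)c1`: in this assay compound 3 gives > 69 ug/mL, a limit of the assay.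

Compound 3 thus stands at a limit rather than at a number (the limit of > 69 ug/mL in this assay, at which 1 of the 3 values shown sits). The other two values are limits as well the limit of > 67 ug/mL in this assay, at which 1 of the 3 values shown sits (the limit of > 71 ug/mL in this assay, at which 1 of the 3 values shown sits), so none of the three compounds can be placed in order against another. Compound 4 `Cc1ccc(-c2nc(CN3CCC(C(=O)NCCCN4C[C@H](C)C[C@H](C)C4)CC3)c(C)o2)c(C)c1` differs from compound 3 in one place: 2,4-dimethylphenyl in place of 3-methylphenyl on an aromatic carbon. Among the compounds with values here, no step between measured compounds is available here. Any step from compound 3 to compound 4 in this assay is expected to stay within the scatter, with the value most likely reported again as a limit. Compound 4 is therefore expected to give 65 ug/mL, in a range of 35 ug/mL to 110 ug/mL. The step this estimate means, an at least 1.0-fold lower number from compound 3 to compound 4 (0.02 log units; that floor lies within the scatter), is expected to be small.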

Compound 4, solubility: > 71 ug/mL
Compound 4: no number, only a limit; the forecaster's own chance of this, stated with the estimate: 70%; middle value at least 1.0-fold (0.03 log units) from the limit.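

Compound 3 and compound 4 both stand at limits in this assay, so no step can be read for 2,4-dimethylphenyl in place of 3-methylphenyl. The compounds shown leave open the actual solubility of each compound.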